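Methylating a Phenol Oxygen in a Small Cytotoxicity Series

The source may hold more compounds than are shown below. What is called first, only, known or untested is meant among the compounds shown, and "the series" means these compounds.

Compound 1 `COc1ccc(CNC(=N)[C@@H]2CCC(=O)N2Cc2ccccc2[N+](=O)[O-])cc1` gives 18.1% in a functional assay on SH-SY5Y cells (Homo sapiens) for cytotoxicity, read by MTT assay, with stated times of 8 h, 30 min and 12 h, tested at 0.05 uM; a higher number here means a stronger effect of the compound at the concentration tested, a lower number a weaker effect. Compound 2 `COc1ccc(CNC(=N)[C@@H]2CCC(=O)N2Cc2ccc(OC)cc2)cc1` gives 24.2% in this assay. Compound 3 `Cc1ccc(CN2C(=O)CC[C@H]2C(=N)NCc2ccc(O)cc2)cc1` gives 20.5% in this assay.

Compound 3 thus has the second highest of these three numbers, but its nearest neighbour is compound 1 and its furthest is compound 2, and both gaps lie within the usual scatter, so the three compounds cannot be told apart on these measurements.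

Compound 4 `COc1ccc(CNC(=N)[C@@H]2CCC(=O)N2Cc2ccc(C)cc2)cc1` is the next compound to be measured. It differs from compound 3 by methyl in place of hydrogen on an oxygen on an aromatic ring.

For the measured compounds named here, only one measured step connects two compounds that differ in a single place: a number 6.1 percentage points higher from compound 1 to compound 2 (within the scatter). That step alters a different part of the molecule, the group on the saturated chain carbon bound to the amide-type nitrogen in the ring, and it stays within the scatter. Going by the values given here, no measured step touches the oxygen on the aromatic ring, so there is no direct precedent for the change from hydrogen to methyl there. Given that every measured compound in this series reads close to the same level, no step beyond the scatter is expected in this assay.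

Compound 4 is therefore estimated at 22%, with a range from 11% to 33%. The expected step from compound 3 is a number 1.5 percentage points higher from compound 3 to compound 4 (within the scatter), which is within the scatter.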

Compound 4, a percentage reported as activity, at one concentration (the size of the read-out at that concentration, not a potency): 19.5%
The estimate for compound 4 lay 2.5 percentage points above the measured number, and the stated range covers the measured number.
By their numbers in this assay, from the lowest: compounds 1, 4, 3 and 2 (each within the scatter of the next).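

Methyl in place of hydrogen on the oxygen on the aromatic ring, which turns 4-hydroxyphenyl into 4-methoxyphenyl, gives a number 1 percentage points lower from compound 3 to compound 4 (within the scatter) in this assay, the first reading of any change at this position, so in this pair the hydrogen on that oxygen can be capped with no step beyond the scatter. For the compounds shown here, compound 4 also extends the picture at the other benzyl-type group: methyl in place of methoxy on an aromatic carbon gives a number 4.7 percentage points lower from compound 2 to compound 4 (within the scatter), and 4-methylphenyl in place of 2-nitrophenyl gives a number 1.4 percentage points higher from compound 1 to compound 4 (within the scatter), so all the single changes read so far in this assay stay within the scatter. Nothing shown explains why these steps are so small.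

On these data alone, whether an ethyl group or a longer chain on that oxygen, or an amine or a carboxylic acid in place of the hydroxy group, would give a step beyond the scatter remains open. As far as these compounds go, the hydrogen-to-methyl change also rests on a single pair at a single concentration, so it remains open whether it would read the same with another group at the far end of the molecule.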